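The source may report more compounds than this note shows. Statements on the series, on what has been measured and on what is new or still open speak of the compounds shown alone.

Of the compounds shown here, three sharing one core have been measured in an ADME assay on J774 cells (Mus musculus) for cytotoxicity, read by MTT assay, with a stated time of 48 h, tested at 50 ug/mL; a higher number here means a weaker effect of the compound at the concentration tested, a lower number a stronger effect. Compound 1 `O=C(N/N=C/c1ccccc1Cl)c1cnccn1` gives 70% in this assay, compound 2 `O=C(N/N=C/c1cccc(F)c1)c1cnccn1` gives 49%, and compound 3 `N#Cc1ccc(/C=N/NC(=O)c2cnccn2)cc1` gives 100%. Among these three, compound 2 stands lowest, meaning the strongest effect at the tested concentration; its nearest neighbour is compound 1, whose number lies higher by a margin beyond the usual scatter, and the furthest is compound 3, higher still by a margin well beyond it.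

The next compound, compound 4 `O=C(N/N=C/c1cccc([N+](=O)[O-])c1)c1cnccn1`, has not yet been measured in this assay. It differs from compound 2 by a single change: nitro in place of fluoro on an aromatic carbon. Going by the values given here, no step between two measured compounds matching this change is available, so the expectation rests only on the three numbers at hand. Compound 1 gives 70% and compound 3 gives 100%, whereas compound 2 gives 49%, the lowest of the three. On that basis a step upward from compound 2 is expected, of modest size and possibly no larger than the scatter. The step from compound 2 to compound 4 in this assay is estimated at a number 21 percentage points higher from compound 2 to compound 4 (beyond the scatter). Compound 4 is expected to give about 70% in this assay, within a range from 45% to 100%.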

Compound 4, a percentage reported as activity, at one concentration (the size of the read-out at that concentration, not a potency): 100%
Compound 4: middle estimate off by 30 percentage points, on the low side; measured number inside the range.
By their numbers in this assay, from the lowest: compound 2; then compound 1; then compounds 3 and 4 (each within the scatter of the next).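

On this carbon of the aromatic ring, meta to a large group, the choice of substituent clearly matters: replacing fluoro with nitro gives a number 51 percentage points higher from compound 2 to compound 4 (beyond the scatter) in this assay, a large step beyond the scatter. The earlier compounds shown here could not show this, since none of them formed a pair differing only in one place, whereas this single change turns the stronger effect of compound 2 into a much weaker one. The change swaps one heavy atom with no hydrogen-bond acceptors for three heavy atoms with two acceptors, but nothing available explains why the step is so large.

With only fluoro and nitro compared here, a single step cannot show a trend across groups at this carbon. An amine or a methoxy group in the same place could fall near either compound, or outside both.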